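The source may hold more compounds than are shown below. What is called first, only, known or untested is meant among the compounds shown, and "the series" means these compounds.

In an ADME assay on CEM-SS cells (Homo sapiens) for cytotoxicity, read by XTT assay, with a stated time of 6 days (a lower number here means that less compound is tolerated, a higher number that more compound is tolerated), compound 1 `CCCC(=O)OCSc1ccccc1C(=O)NCCCCC(N)=O` gives 51.7 uM as the highest of three numbers. Compound 2 `CCCC(=O)OCSc1ccccc1C(=O)NCCCCCC(N)=O` stands at 16.3 uM and compound 3 `CCCC(=O)OCSc1ccccc1C(=O)NCCCCNC(C)=O` stands at 17.4 uM with only a 1.1-fold higher number from compound 2 to compound 3 (0.03 log units; within the scatter) between them. Compound 4 `CCCC(=O)OCSc1ccccc1C(=O)N(C)CC(=O)N(C)C` has not yet been measured. The change from compound 1 is ((dimethylcarbamoyl)methyl)(methyl)amino in place of (4-carbamoylbutyl)amino on a carbonyl carbon and it puts ((dimethylcarbamoyl)methyl)(methyl)amino in place of (4-carbamoylbutyl)amino on a carbonyl carbon. Going by the values given here, two measured steps bear on this change. They are a 3.2-fold lower number from compound 1 to compound 2 (0.50 log units; beyond the scatter) and a 3.0-fold lower number from compound 1 to compound 3 (0.47 log units; beyond the scatter) and both are modest and point the same way. Both of these compounds keep the amide hydrogen, and no measured compound lacks it, so the two steps guide the expectation only loosely. A modest step to a lower number is therefore expected, no larger than those two, and a 1.7-fold lower number from compound 1 to compound 4 (0.24 log units; within the scatter) is the estimated step in this assay for this change. Compound 4 is expected at 30 uM with an estimated range from 12 uM to 80 uM once it is measured.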

Compound 4, half-maximal toxic concentration: 57.3 uM
Compound 4: the middle estimate sits 1.9-fold (0.28 log units) below what was measured, within the range that was stated.
By their numbers in this assay, from the lowest: compounds 2 and 3 (each within the scatter of the next); then compounds 1 and 4 (each within the scatter of the next).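

In this assay, ((dimethylcarbamoyl)methyl)(methyl)amino in place of (4-carbamoylbutyl)amino on a carbonyl carbon gives a 1.1-fold higher number from compound 1 to compound 4 (0.04 log units; within the scatter), so the whole group can be exchanged without a change beyond the scatter. Compound 4 is the first shown without the amide hydrogen, and its group has 0 hydrogen-bond donors against 2 in compound 1, yet this step stays within the scatter, unlike the steps from compound 1 to compounds 2 and 3. Nothing available explains this result. From the compounds shown here alone, the change alters the amide nitrogen, the chain and the terminal amide at once, so the part each contributes remains open. Also open, going by these compounds, is how the number would respond to a terminal amine or a carboxylic acid on the chain.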